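Methoxy added to the fused ring of compound 2

The source may report more compounds than this note shows. Statements on the series, on what has been measured and on what is new or still open speak of the compounds shown alone.

Measured compounds:
Compound 1, `COc1ccc(-c2c(Nc3ccc(F)cc3)c3ccccc3oc2=O)cc1`; in a functional assay on PANC-1 cells (Homo sapiens) for antiproliferative activity, read by MTT assay, with a stated time of 48 h (on this read-out lower numbers stand for stronger inhibition and higher numbers for weaker inhibition), compound 1 gives 32000 nM.
Compound 2, `COc1ccc(-c2c(Nc3ccc(C)c(O)c3)c3ccccc3oc2=O)cc1`; in this assay compound 2 gives 9750 nM.
Compound 3, `COc1ccc(-c2c(Nc3ccc(NC(C)=O)cc3)c3ccccc3oc2=O)cc1`; in this assay compound 3 gives "not determined" (no result reported), that is, no result is reported for it.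

Going by the values given here, compound 2 stands with the lowest of the two numbers in this assay; its nearest neighbour is compound 1, and the only step, a 3.3-fold lower number from compound 1 to compound 2 (0.52 log units; beyond the scatter), changes the aryl group on the nitrogen and nothing else. Among the compounds with values here, the single step therefore runs on the aniline side of the shared core.

Compound 4, `COc1ccc(-c2c(Nc3ccc(C)c(O)c3)c3ccc(OC)cc3oc2=O)cc1`, keeps the 3-hydroxy-4-methylphenyl of compound 2 and differs only on the fused ring: methoxy in place of hydrogen on an aromatic carbon.

Within the data shown here, no measured step touches the fused ring, so nothing speaks to the size or direction of this change. The step from compound 1 to compound 2 concerns a different place and does not carry over. The working expectation is a step in this assay that stays within the scatter, either way, estimated as a 1.1-fold lower number from compound 2 to compound 4 (0.03 log units; within the scatter).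

Compound 4 is accordingly estimated at 9000 nM, with a range from 3500 nM to 25000 nM, the width reflecting the absence of any comparable step.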

Compound 4, half-maximal inhibitory concentration: 31300 nM
Compound 4: the middle estimate sits 3.5-fold (0.54 log units) below what was measured; the whole stated range lies below it.
By their numbers in this assay, from the lowest: compound 2; then compounds 4 and 1 (each within the scatter of the next).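

Going by these compounds alone, the fused ring is not a silent position: in this assay methoxy in place of hydrogen on an aromatic carbon gives a 3.2-fold higher number from compound 2 to compound 4 (0.51 log units; beyond the scatter), the first measured step at this place and one toward weaker inhibition. In size it stands with a 3.3-fold lower number from compound 1 to compound 2 (0.52 log units; beyond the scatter), which runs the other way at a different place, so within these compounds a change on the fused ring weighs about as much as a change of the aryl group on the nitrogen. Nothing measured here accounts for this step.

Only methoxy is shown at this carbon, so it stays open whether the step belongs to methoxy itself or to any group placed there; an amine, a carboxylic acid or a longer chain such as ethoxy would separate the two. Also open, as far as these compounds go, is whether the step holds with another aryl group on the nitrogen, such as the 4-fluorophenyl of compound 1, and steps involving compound 3 cannot be read, as it has no number.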